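Bromo on the ring: the step from compound 1 to compound 4

The compounds below may be only part of what the source reports. "The series", "measured", "known", "first", "only" and "open" are said of these compounds alone.

Of the compounds shown here, three that share a core have been measured so far. Compound 1 `O=C1C=CC(OCC(F)(F)F)N1c1ccccc1` gives 15300 nM in a functional assay on MDA-MB-231 cells (Homo sapiens) for inhibition; a lower number here means a stronger inhibitor, a higher number a weaker inhibitor. Its number lies within the scatter of compound 3 `O=C1C=CC(OCC(F)(F)F)N1c1ccccc1F`, which gives 20600 nM, and well above compound 2 `O=C1C=CC(OCC(F)(F)F)N1c1ccc(F)c(Cl)c1`, which gives 3440 nM. Within the data shown here, the only measured step that changes a single place is a 1.3-fold higher number from compound 1 to compound 3 (0.13 log units; within the scatter), so a fluoro alone has not moved the number. Among the measured compounds shown here, compound 2, however, carries both a fluoro and a chloro and reaches a number that is beyond the scatter lower than that of compound 1, though no single step can be separated out there.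

Compound 4 `O=C1C=CC(OCC(F)(F)F)N1c1ccc(Br)cc1` differs from compound 1 by bromo in place of hydrogen on an aromatic carbon, placed para to a large group. For the measured compounds named here, no measured step tests this place, so the expectation leans on compound 2, whose value 3440 nM shows that halogens on this ring can lower the number. A modest improvement is therefore expected, a 2.4-fold lower number from compound 1 to compound 4 (0.37 log units; beyond the scatter), and compound 4 is estimated at 6500 nM, between 2500 nM and 17000 nM.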

Compound 4, half-maximal inhibitory concentration: 7570 nM
The estimate for compound 4 lay 1.2-fold (0.07 log units) below the measured number; the range from low to high includes it.
By their numbers in this assay, from the lowest: compound 2; then compound 4; then compounds 1 and 3 (each within the scatter of the next).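

Putting a bromo para to a large group gives a modest drop (a 2.0-fold lower number from compound 1 to compound 4 (0.31 log units; beyond the scatter)). Among these compounds, this is the first change at a single place in this set that lies beyond the scatter, and it shows that one halogen alone can lower the number. It does not hold for every halogen change on this ring, since the fluoro step (a 1.3-fold higher number from compound 1 to compound 3 (0.13 log units; within the scatter)) stays within the scatter. No measurement here explains the drop.

The compounds shown leave open whether the step belongs to bromo itself or to any group at this place, which a methoxy group, an amine or a carboxylic acid at the same carbon would help to separate. They also leave open whether bromo elsewhere on the ring would give a similar step.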